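Dropping One Methoxy Group from Compound 3

The source may report more compounds than this note shows. Statements on the series, on what has been measured and on what is new or still open speak of the compounds shown alone.

In an ADME assay on NIH3T3 cells (Mus musculus) for cytotoxicity, read by MTT assay, with a stated time of 72 h (a lower number here means a stronger inhibitor, a higher number a weaker inhibitor), compound 1 `COc1ccc(/C=C/c2cc(C)n[nH]2)cc1` gives 19900 nM and compound 3 `COc1ccc(/C=C/C(=O)CC(C)=O)cc1OC` gives 18100 nM, two values within the scatter of each other. Compound 2 `COc1ccc(/C=C/c2cc(C)no2)cc1OC` gives 93200 nM. Compound 3 therefore stands level with compound 1 at the low end of these numbers. Compound 4 `COc1ccc(/C=C/C(=O)CC(C)=O)cc1` has hydrogen in place of methoxy on an aromatic carbon of compound 3: hydrogen in place of methoxy on an aromatic carbon. Among the measured compounds shown here, the only measured step, a 5.1-fold lower number from compound 2 to compound 3 (0.71 log units; beyond the scatter), is modest and changes a different place, so no measured step tests this change directly. In this assay, no step beyond the scatter is therefore expected, and the estimated step is a 1.1-fold higher number from compound 3 to compound 4 (0.04 log units; within the scatter). Compound 4 is expected to give 20000 nM, with an estimated range of 8000 nM to 50000 nM.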

Compound 4, half-maximal inhibitory concentration: 48200 nM
The estimate for compound 4 lay 2.4-fold (0.38 log units) below the measured number, and the stated range covers the measured number.
By their numbers in this assay, from the lowest: compounds 3 and 1 (each within the scatter of the next); then compounds 4 and 2 (each within the scatter of the next).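

In this assay, the methoxy group on this aromatic carbon, ortho to a methoxy group, proves to matter: replacing it with hydrogen gives a 2.7-fold higher number from compound 3 to compound 4 (0.43 log units; beyond the scatter). Among the compounds shown here, this is the first step at this aromatic carbon, since the earlier step changed only the group on the chain, and it shows that the ring substitution also moves the number. Nothing available explains why this change has this effect. On these data alone, what remains open is whether a hydroxy, ethoxy or fluorine group on this carbon would match methoxy or hydrogen. Also open, as far as these compounds go, is whether the same loss of methoxy would shift the number similarly with the 3-methyl-1,2-oxazol-5-yl group on the chain.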